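The compounds below may be only part of what the source reports. "The series", "measured", "known", "first", "only" and "open" are said of these compounds alone.

Among the compounds with values here, compound 1 `Cc1cn([C@@H]2O[C@H](CO[Si](C)(C)C(C)(C)C)[C@@]3(OS(=O)(=O)C=C3NCC(=O)O)[C@H]2O[Si](C)(C)C(C)(C)C)c(=O)n(C)c1=O` stands at the top of the three numbers measured so far in a functional assay on HEL cells (Homo sapiens); on this read-out higher numbers stand for lower toxicity in this test and lower numbers for higher toxicity in this test: in that assay compound 1 gives 136000 nM. Compound 2 `Cc1cn([C@@H]2O[C@H](CO[Si](C)(C)C(C)(C)C)[C@@]3(OS(=O)(=O)C=C3NCCC(=O)O)[C@H]2O[Si](C)(C)C(C)(C)C)c(=O)n(C)c1=O` gives 34000 nM in this assay, and compound 3 `Cc1cn([C@@H]2O[C@H](CO[Si](C)(C)C(C)(C)C)[C@@]3(OS(=O)(=O)C=C3NCC(=O)C(N)=O)[C@H]2O[Si](C)(C)C(C)(C)C)c(=O)n(C)c1=O` gives 14500 nM. Both lie below compound 1, since a 4.0-fold lower number from compound 1 to compound 2 (0.60 log units; beyond the scatter) and a 9.4-fold lower number from compound 1 to compound 3 (0.97 log units; beyond the scatter); between the two lower compounds, a 2.3-fold lower number from compound 2 to compound 3 (0.37 log units; beyond the scatter).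

Compound 4 `Cc1cn([C@@H]2O[C@H](CO[Si](C)(C)C(C)(C)C)[C@@]3(OS(=O)(=O)C=C3NCCC(N)=O)[C@H]2O[Si](C)(C)C(C)(C)C)c(=O)n(C)c1=O` has not yet been measured in this assay. Compared with compound 1 it carries the change (carbamoylmethyl in place of carboxy on a saturated chain carbon bound to an amine nitrogen). Two of the measured steps bear on it. The longer chain on the amine nitrogen, carboxymethyl in place of carboxy, gave a 4.0-fold lower number from compound 1 to compound 2 (0.60 log units; beyond the scatter). The exchange of hydroxy for carbamoyl on the carbonyl carbon gave a 9.4-fold lower number from compound 1 to compound 3 (0.97 log units; beyond the scatter). Compound 4 joins both alterations in one molecule, a longer chain and an amide end, and each alone moved the number downward beyond the scatter, so a drop of similar size, in the same direction, is expected here. The estimated step is a 6.2-fold lower number from compound 1 to compound 4 (0.79 log units; beyond the scatter), a modest lowering rather than a large one. Compound 4 is therefore expected to give about 22000 nM in this assay, with a plausible range from 7000 nM to 70000 nM.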

Compound 4, half-maximal cytotoxic concentration: 14800 nM
Estimate against measurement, compound 4: 1.5-fold (0.17 log units) above, and the stated range covers the measured number.
By their numbers in this assay, from the lowest: compounds 3 and 4 (each within the scatter of the next); then compound 2; then compound 1.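

In this assay, 2-carbamoylethyl in place of carboxymethyl on the amine nitrogen gives a 9.2-fold lower number from compound 1 to compound 4 (0.96 log units; beyond the scatter), so this position tolerates a change of both chain and end group with a lowering that stays modest. Within the data shown here, compound 2 and compound 4 offer the first comparison in which only the chain end changes: amino in place of hydroxy on a carbonyl carbon gives a 2.3-fold lower number from compound 2 to compound 4 (0.36 log units; beyond the scatter), which shows that the amide end alone lowers the number when the longer chain is held constant. Carbamoylmethyl in place of carbamoylcarbonyl gives a 1.0-fold higher number from compound 3 to compound 4 (0.01 log units; within the scatter), so the two carbamoyl-ended chains cannot be told apart on this read-out, and the carbonyl that separates them makes no visible difference here.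

No measurement given here accounts for any of these steps. Going by these compounds, it remains open how a longer chain ending in a carbamoyl group, or an amine or a methyl ester at the chain end, would read in this assay, and whether the lowering seen with the amide end would continue.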